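This account rests on a few compounds, and the source may have more. Where it says the series, first, only, none or still open, it means among the compounds named here.

Working notes on the series

The series shares a core, seen in compound 1 `COc1cccc(-c2ccc(COCCCCCN3C[C@H](O)[C@@H](O)[C@H](O)[C@H]3CO)cc2)c1`, in which a five-carbon chain links the iminosugar to a benzyl ether carrying a biaryl. In an assay on isolated protein for inhibition of Beta-glucosidase (Homo sapiens) (a higher number here means a weaker inhibitor, a lower number a stronger inhibitor), compound 1 gives 20 nM. Compound 2 `OC[C@@H]1[C@@H](O)[C@H](O)[C@@H](O)CN1CCCCCOCc1ccc(-c2ccc(C(F)(F)F)cc2)cc1` gives 10 nM in this assay, and compound 3 `OC[C@@H]1[C@@H](O)[C@H](O)[C@@H](O)CN1CCCCCOCc1ccc(-c2ccc3c(c2)OCCO3)cc1` gives 30 nM. Among the three numbers compound 3 sits highest; its nearest neighbour is compound 1, the step of a 1.5-fold higher number from compound 1 to compound 3 (0.18 log units; within the scatter), and the step of a 3.0-fold higher number from compound 2 to compound 3 (0.48 log units; beyond the scatter) is the largest gap in the set. The step of a 2.0-fold lower number from compound 1 to compound 2 (0.30 log units; within the scatter) stays within the scatter, so the three terminal aryl groups span only a narrow band of potency.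

Compound 4 `OC[C@@H]1[C@@H](O)[C@H](O)[C@@H](O)CN1CCCCCOCc1ccc(-c2ccnc(F)c2)cc1` is made from compound 3 by the change (2-fluoropyridin-4-yl in place of 2,3-dihydro-1,4-benzodioxin-6-yl on an aromatic carbon). Going by the values given here, no measured step swaps a fused bicyclic aryl for a six-membered aromatic ring with one hetero atom, but the three earlier aryl changes moved this assay by no more than the step from compound 2 to compound 3. A step of similar modest size, in either direction, is therefore expected, estimated as a 1.5-fold lower number from compound 3 to compound 4 (0.18 log units; within the scatter). For compound 4 in this assay the expected value is 20 nM, within 7 nM to 60 nM.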

Compound 4, half-maximal inhibitory concentration: 4 nM
Beside the measured number, compound 4's estimate is 5.0-fold (0.70 log units) above it, outside the stated range (below it).
By their numbers in this assay, from the lowest: compound 4; then compounds 2, 1 and 3 (each within the scatter of the next, the first and the last beyond it).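

Going by these compounds alone, the 2-fluoropyridin-4-yl group is the only terminal group here with a hetero atom in its aromatic ring, and in this assay it gives a 7.5-fold lower number from compound 3 to compound 4 (0.88 log units; beyond the scatter) and a 2.5-fold lower number from compound 2 to compound 4 (0.40 log units; beyond the scatter) and a 5.0-fold lower number from compound 1 to compound 4 (0.70 log units; beyond the scatter), which makes compound 4 the strongest inhibitor of the four. The narrow band of potency seen for compounds 1, 2 and 3 therefore does not describe this position as a whole, and a smaller ring system can still give the lowest number. Nothing available explains this result.

Whether the ring nitrogen, the fluorine or both account for these steps stays open; a plain pyridin-4-yl or a 3-fluorophenyl group would separate the two. Also open, as far as these compounds go, is whether the lower number survives with a 2-aminopyridin-4-yl group or a longer chain to the iminosugar.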